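The compounds below may be only part of what the source reports. "The series", "measured", "known", "first", "only" and "open" are said of these compounds alone.

Going by the values given here, in an ADME assay on the whole organism (Mus musculus, strain Swiss Webster) for pharmacokinetics, read by LC-MS, at a dose of 50 mg/kg by the oral route (a lower number here means less compound in the circulation, a higher number more compound in the circulation at the dose given), compound 2 `O=C(Nc1ccc(F)c(-c2nc3ncc(-c4cc(F)cc(F)c4)cc3[nH]2)c1)N1CCCC1` gives 4800 nM, the higher of the two numbers so far, while compound 1 `O=C(Nc1ccc(F)c(-c2nc3ncc(-c4cncc(F)c4)cc3[nH]2)c1)N1CCCC1` gives 1070 nM. Compound 3 `O=C(Nc1ccc(F)c(-c2nc3ncc(-c4ccccc4F)cc3[nH]2)c1)N1CCCC1` keeps the shared core and changes the same group again, with 2-fluorophenyl in place of 3,5-difluorophenyl on an aromatic carbon. Among the compounds with values here, only one measured step bears on this, a 4.5-fold higher number from compound 1 to compound 2 (0.65 log units; beyond the scatter), a modest one made at the same place. It swapped a different pair of groups, so it shows how far the number has moved at this place but gives no direction for the new change. Both groups in the new change are a six-membered aromatic ring of carbon only, so a smaller step is expected in this assay, possibly none beyond the scatter. A slight lean downward is assumed, as compound 2 stands at the top of just two numbers. The maximal plasma concentration of compound 3 is expected at 3000 nM, with an estimated range from 1100 nM to 8000 nM. The expected step is a 1.6-fold lower number from compound 2 to compound 3 (0.20 log units; within the scatter).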

Compound 3, maximal plasma concentration: 2230 nM
Compound 3: the middle estimate sits 1.3-fold (0.13 log units) above what was measured, within the range that was stated.
By their numbers in this assay, from the lowest: compound 1; then compound 3; then compound 2.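

Replacing 3,5-difluorophenyl with 2-fluorophenyl gives a 2.2-fold lower number from compound 2 to compound 3 (0.33 log units; beyond the scatter) in this assay and shows that, at this place, a change between two six-membered aromatic rings of carbon only can still move the maximal plasma concentration beyond the scatter. Going by these compounds alone, replacing 5-fluoropyridin-3-yl with 2-fluorophenyl gives a 2.1-fold higher number from compound 1 to compound 3 (0.32 log units; beyond the scatter) and places compound 3 between the other two, so both rings of carbon only stand above the ring with nitrogen in these three compounds, with no compound going against that order. Nothing independent is available here to account for either step.

The two carbon-only rings differ in both the number and the place of their fluorine atoms, so these compounds leave open which of the two goes with the change in circulating compound. Also open, on these data alone, is how an unsubstituted phenyl, a methoxy-bearing phenyl or a saturated amine such as morpholine would compare on this same aromatic carbon, and whether the order of the three rings would hold with any other group in place of the pyrrolidine urea.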